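Oxygen to Sulfur on the Dichlorophenyl Arm

This account rests on a few compounds, and the source may have more. Where it says the series, first, only, none or still open, it means among the compounds named here.

Measured compounds:
Compound 1 `Nc1cc(N)c2nc(-c3ccccc3)c(Oc3ccc(Cl)c(Cl)c3)nc2c1` gives 66100 nM in a functional assay on OVCAR-3 cells (Homo sapiens) for inhibition, read by sulforhodamine B assay, with a stated time of 48 h; on this read-out higher numbers stand for lower toxicity in this test and lower numbers for higher toxicity in this test.
Compound 2 `CCOC(=O)[C@H](CCC(=O)O)NC(=O)c1ccc(CNc2nc3cc(N)cc(N)c3nc2-c2ccccc2)cc1` gives < 100000 nM in this assay, which is a limit of the assay and not a number.
Compound 3 `CCOC(=O)[C@H](CCC(=O)O)NC(=O)c1ccc(Sc2nc3cc(N)cc(N)c3nc2-c2ccccc2)cc1` gives < 100000 nM in this assay, again a limit rather than a measured number.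

Among the measured compounds shown here, compound 1 therefore stands as the only true number among the three measured compounds. The other two sit at the limit of < 100000 nM in this assay, at which 2 of the 3 values shown sit, so they cannot be placed above or below compound 1, and no comparison between any two of them can be drawn. For the measured compounds named here, no pair of measured compounds differs in just one place, so the data give no measured step to lean on.

Compound 4 `Nc1cc(N)c2nc(-c3ccccc3)c(Sc3ccc(Cl)c(Cl)c3)nc2c1` has not yet been measured. It differs from compound 1 by (3,4-dichlorophenyl)sulfanyl in place of 3,4-dichlorophenoxy on an aromatic carbon, in words: (3,4-dichlorophenyl)sulfanyl in place of 3,4-dichlorophenoxy on an aromatic carbon. Going by the values given here, nothing among the measured compounds shows what this single exchange does to cell killing, so the expectation rests on compound 1 alone. The change is expected to be a 1.2-fold lower number from compound 1 to compound 4 (0.08 log units; within the scatter), a shift no larger than the usual scatter and in no particular direction. Compound 4 is thus estimated at 55000 nM in this assay, with a range from 20000 nM to 100000 nM.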

Compound 4, concentration lethal to 50% of the cells: < 100000 nM
Compound 4: only a limit was reported; the forecaster's own chance of this, stated with the estimate: 25%; the middle value lies beyond the limit too.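

No new step can be read from compound 1 to compound 4, because compound 4 is reported only as a limit of the assay and not as a number: the limit of < 100000 nM in this assay, at which 3 of the 4 values shown sit.

The compounds shown leave open whether (3,4-dichlorophenyl)sulfanyl in place of 3,4-dichlorophenoxy changes the result in this assay at all, and in which direction.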